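The source may hold more compounds than are shown below. What is called first, only, known or untested is meant among the compounds shown, and "the series" means these compounds.

Series notes. In a functional assay for inhibition, with a stated time of 5 min, tested at 1 mM (a lower number here means less inhibition, a higher number more inhibition at the concentration tested (going by the name of the read-out)), compound 1 `COc1cc(/C(Cl)=C/C=C(\C#N)C(=O)c2c[nH]c3ccccc23)cc(OC)c1OC` gives 59.1% and compound 2 `COc1ccc(/C(Cl)=C/C=C(\C#N)C(=O)c2c(C)[nH]c3ccccc23)cc1` gives 63.1%, the two within the scatter of each other. Going by the values given here, compound 3 `COc1cc(/C(Cl)=C/C=C(\C#N)C(=O)c2c[nH]c3ccc(Br)cc23)cc(OC)c1OC` gives 50%, the only one-place step measured being a number 9.1 percentage points lower from compound 1 to compound 3 (within the scatter). Compound 2 thus stands with compound 1 within scatter and compound 3 beyond it, lower.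

Compound 4 `COc1ccc(/C(Cl)=C/C=C(\C#N)C(=O)c2c[nH]c3ccccc23)cc1` arises from compound 2 by hydrogen in place of methyl on an aromatic carbon. Among the compounds with values here, no measured pair shows this change, and the bromo step does not bear on it. Compounds 1 and 4 share the unmethylated core but also differ elsewhere, so compound 1 is only a loose anchor. For compound 4 a step of a number 5.1 percentage points lower from compound 2 to compound 4 (within the scatter) is expected, not beyond the scatter. Compound 4 is estimated at 58%, range 45% to 70%.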

Compound 4, a percentage reported as inhibition, at one concentration (the size of the read-out at that concentration, not a potency): 61.3%
The estimate for compound 4 lay 3.3 percentage points below the measured number; low and high end bracket the measured number.
By their numbers in this assay, from the lowest: compounds 3, 1, 4 and 2 (each within the scatter of the next, the first and the last beyond it).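

Hydrogen in place of methyl on this aromatic carbon, next to the ring nitrogen, gives in this assay a number 1.8 percentage points lower from compound 2 to compound 4 (within the scatter). This first measured pair for the position shows that, at the single concentration tested, the methyl group is not needed to keep the read-out. No measured evidence bears on why the two compounds read alike.

Going by these compounds, whether an ethyl group, an amine or a carboxylic acid at this place would move the number stays open. Also open, on these data alone, is whether methyl and hydrogen would read alike on the core of compound 1.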